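Swapping Bromo for Methoxy on a Urea Series

This account rests on a few compounds, and the source may have more. Where it says the series, first, only, none or still open, it means among the compounds named here.

Compound 1 `COc1ccc(Br)cc1Nc1cc(NC(=O)Nc2c(Cl)cccc2Cl)ncn1` gives 45% in a functional assay on NCI-H520 cells (Homo sapiens) for inhibition, read by MTT assay, with a stated time of 48 h, tested at 10 uM (a lower number here means less inhibition, a higher number more inhibition at the concentration tested (going by the name of the read-out)), and stands highest of the two measured numbers. Compound 2 `O=C(Nc1cc(Nc2ccc(F)c(Cl)c2)ncn1)Nc1c(Cl)cccc1Cl` gives 39.5% in this assay, and the step of a number 5.5 percentage points lower from compound 1 to compound 2 (within the scatter) lies within the scatter. Compound 3 `COc1ccc(OC)c(Nc2cc(NC(=O)Nc3c(Cl)cccc3Cl)ncn2)c1` differs from compound 1 in one place: methoxy in place of bromo on an aromatic carbon. Going by the values given here, the only measured step changes a different ring and is small, so no direct guide exists for this swap; the expected step of a number 3 percentage points lower from compound 1 to compound 3 (within the scatter) is therefore none beyond the scatter. Compound 3 is estimated at 42%, with a range from 25% to 58%.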

Compound 3, a percentage reported as inhibition, at one concentration (the size of the read-out at that concentration, not a potency): 74%
Compound 3: the middle estimate sits 32 percentage points below what was measured; measured number above the stated range.
By their numbers in this assay, from the lowest: compounds 2 and 1 (each within the scatter of the next); then compound 3.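

Methoxy in place of bromo, para to a methoxy group, brings a number 29 percentage points higher from compound 1 to compound 3 (beyond the scatter) and so shows that this position responds strongly to a change of a single group, something the earlier step on the other side of the amine nitrogen did not reveal. Nothing available here accounts for the rise. Still open, as far as these compounds go, is whether the higher number belongs to methoxy in particular or would also come with an amine, a hydroxyl group or a longer ether chain at this position.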